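Nitro in Place of Chloro: What to Expect for Compound 4

This account rests on a few compounds, and the source may have more. Where it says the series, first, only, none or still open, it means among the compounds named here.

Compound 1 `O=C(Cn1c(=O)oc2cc(Cl)ccc21)Nc1cc(C(F)(F)F)ccc1Cl` and compound 2 `O=C(Cn1c(=O)oc2cc(Cl)ccc21)NCc1ccco1` share a core but carry different amide portions; the difference between the two cores is not broken down here. In an ADME assay on RAW264.7 cells (Mus musculus) for cytotoxicity, read by MTT assay, with a stated time of 72 h, tested at 100 uM (a lower number here means a weaker effect, a higher number a stronger effect of the compound at the concentration tested), compound 1 gives 12.1%, while compound 2 gives 50.3%. Compound 3 `O=C(Cn1c(=O)oc2cc([N+](=O)[O-])ccc21)NCc1ccco1` differs from compound 2 by nitro in place of chloro on an aromatic carbon, and in this assay compound 3 gives 60.1%, a step of a number 9.8 percentage points higher from compound 2 to compound 3 (within the scatter). Compound 4 `O=C(Cn1c(=O)oc2cc([N+](=O)[O-])ccc21)Nc1cc(C(F)(F)F)ccc1Cl`, not yet measured, stands to compound 1 as compound 3 stands to compound 2, through (nitro in place of chloro on an aromatic carbon), with the place described in the same words for both pairs. Because compound 1 gives 12.1% and the earlier step of the same kind lay within the scatter, the expected step is a number 7.9 percentage points higher from compound 1 to compound 4 (within the scatter). In this assay compound 4 is therefore estimated at 20%, most likely between 5% and 38%.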

Compound 4, a percentage reported as inhibition, at one concentration (the size of the read-out at that concentration, not a potency): 31.6%
For compound 4 the middle estimate is 11.6 percentage points below the measured one; the measured number falls inside the stated range.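

In this assay, nitro in place of chloro gives a number 19.5 percentage points higher from compound 1 to compound 4 (beyond the scatter). Set beside the same change on the other core, this step does not differ from the earlier one by more than the scatter, so the two cores give no sign that the change behaves differently between them: the same change on two cores in this assay, a number 9.8 percentage points higher (within the scatter) from compound 2 to compound 3 and a number 19.5 percentage points higher (beyond the scatter) from compound 1 to compound 4, 9.7 percentage points apart, within the scatter of two such steps This rests on only two pairs of compounds at a single concentration, so it does not show that the step would hold on other cores, and it gives no reason for the step.

The compounds shown carry only chloro or nitro at this place, so the effect of an amine or a carboxylic acid there remains open. Also open, going by these compounds, is whether the step would persist with other amide portions.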